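Cyclopropyl in place of hexyl on the shared core

The source may hold more compounds than are shown below. What is called first, only, known or untested is meant among the compounds shown, and "the series" means these compounds.

Within the data shown here, compound 2 `CCCCCCc1cc2cn(Cc3cn(Cc4ccccc4)nn3)c(=O)nc2o1` stands at the high end of the two numbers so far: in a functional assay on HeLa cells (Homo sapiens) for antiproliferative activity, read by MTT assay, with a stated time of 72 h (on this read-out lower numbers stand for stronger inhibition and higher numbers for weaker inhibition), compound 2 gives 59400 nM. Its nearest neighbour is compound 1 `CCCCCCC#Cc1c(CCCCCC)oc2nc(=O)n(Cc3cn(Cc4ccccc4)nn3)cc12`, which in this assay gives 23400 nM. Among the measured compounds shown here, the one measured step, a 2.5-fold higher number from compound 1 to compound 2 (0.40 log units; beyond the scatter), is a hydrogen in place of oct-1-yn-1-yl on an aromatic carbon, and it raised the number by a modest but real margin.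

Compound 3 `O=c1nc2oc(C3CC3)cc2cn1Cc1cn(Cc2ccccc2)nn1` differs from compound 2 by cyclopropyl in place of hexyl on an aromatic carbon. For the measured compounds named here, no measured step touches the hexyl chain itself; the step from compound 1 to compound 2 concerns a different substituent and is the only guide available. That step shows a loss of potency when carbon is taken away from the shared core, so a trimmed chain at the other position is expected to move in the same direction, by a step of similar or slightly smaller size, a 2.0-fold higher number from compound 2 to compound 3 (0.31 log units; beyond the scatter).

For compound 3 in this assay the expected value is 120000 nM, with a likely range from 40000 nM to 400000 nM.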

Compound 3, half-maximal inhibitory concentration: 50000 nM
Compound 3: the middle estimate sits 2.4-fold (0.38 log units) above what was measured; the measured number falls inside the stated range.
By their numbers in this assay, from the lowest: compound 1; then compounds 3 and 2 (each within the scatter of the next).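

In this assay, cyclopropyl in place of hexyl on the aromatic carbon next to the ring oxygen gives a 1.2-fold lower number from compound 2 to compound 3 (0.07 log units; within the scatter), so this position does not separate the open hexyl chain from the small non-aromatic ring. Among these compounds, until now the only reading came from the other substituent, where hydrogen in place of oct-1-yn-1-yl gave a 2.5-fold higher number from compound 1 to compound 2 (0.40 log units; beyond the scatter); the series therefore has one change beyond the scatter and one within it, on different positions of the shared core. Nothing available explains why hexyl and cyclopropyl read alike here.

Still open, as far as these compounds go, is whether this flat reading holds for groups of another kind at the same position, such as a longer chain, an amine or a carboxylic acid, or for plain hydrogen in place of hexyl. Also open, from the compounds shown here alone, is whether oct-1-yn-1-yl would give the same step on the cyclopropyl core of compound 3 as it does on the hexyl core, since that substituent has been read only alongside hexyl.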